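The compounds below may be only part of what the source reports. "The series", "measured", "known", "first", "only" and "open" are said of these compounds alone.

Measured compounds and their values:
compound 1 `O=C(/C=C/c1ccc2c(c1)B(O)OC2)c1ccco1` — 7300 nM
compound 2 `O=C(/C=C/c1ccc2c(c1)B(O)OC2)c1ccc(Br)cc1` — 9500 nM
compound 3 `O=C(/C=C/c1ccc2c(c1)B(O)OC2)c1ccc(O)cc1` — 25600 nM

The read-out throughout is a functional assay on MDA-MB-231 cells (Homo sapiens) for cytotoxicity, read by MTT assay, with a stated time of 48 h; on this read-out higher numbers stand for weaker inhibition and lower numbers for stronger inhibition. Compound 3 gives the highest number of the three, with both steps to it beyond the scatter: a 2.7-fold higher number from compound 2 to compound 3 (0.43 log units; beyond the scatter) and a 3.5-fold higher number from compound 1 to compound 3 (0.54 log units; beyond the scatter). On these numbers compound 3 is the weakest inhibitor of the set. Compound 1 and compound 2 sit within the scatter of each other: a 1.3-fold higher number from compound 1 to compound 2 (0.11 log units; within the scatter).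

Compound 4 `Cc1cccc(C(=O)/C=C/c2ccc3c(c2)B(O)OC3)c1` differs from compound 3 by 3-methylphenyl in place of 4-hydroxyphenyl on a carbonyl carbon. Among the measured compounds shown here, the steps that bear on this are the two that exchange the aryl group on the carbonyl carbon, a 3.5-fold higher number from compound 1 to compound 3 (0.54 log units; beyond the scatter) and a 2.7-fold higher number from compound 2 to compound 3 (0.43 log units; beyond the scatter); both are modest in size, and both place the 4-hydroxyphenyl at the high end. Exchanging it for a group with no hydrogen-bond donor or acceptor, as in compound 2, points back toward the numbers of compound 1 and compound 2. Compound 4 is therefore expected to give a modestly lower number, a 2.8-fold lower number from compound 3 to compound 4 (0.45 log units; beyond the scatter). The estimate for compound 4 is 9000 nM, within a range of 4000 nM to 20000 nM.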

Compound 4, half-maximal inhibitory concentration: 4500 nM
For compound 4 the middle estimate is 2.0-fold (0.30 log units) above the measured one, and the stated range covers the measured number.
By their numbers in this assay, from the lowest: compounds 4, 1 and 2 (each within the scatter of the next, the first and the last beyond it); then compound 3.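

In this assay, among the compounds shown here, the largest step so far at this carbonyl carbon is a 5.7-fold lower number from compound 3 to compound 4 (0.76 log units; beyond the scatter), which shows that 3-methylphenyl, with no hydrogen-bond donor or acceptor, does not carry the high number seen with 4-hydroxyphenyl. The position also separates two groups that earlier looked alike against 4-hydroxyphenyl: a 2.1-fold lower number from compound 2 to compound 4 (0.32 log units; beyond the scatter) lies beyond the scatter, whereas a 1.6-fold lower number from compound 1 to compound 4 (0.21 log units; within the scatter) lies within it, so the furan-2-yl and 3-methylphenyl compounds cannot be ordered. No supporting measurement bears on why these steps arise.

On these data alone, it remains open whether the high number of compound 3 belongs to the hydroxy group itself, which an amine or a carboxylic acid on the same phenyl ring would test. As far as these compounds go, it is also open whether the methyl group contributes at all, which an unsubstituted phenyl on the carbonyl carbon would show.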